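Chloro to fluoro on a shared core

The source may hold more compounds than are shown below. What is called first, only, known or untested is meant among the compounds shown, and "the series" means these compounds.

Three compounds with a shared core have been studied in an assay on isolated protein for binding affinity to 5-hydroxytryptamine receptor 1D (Homo sapiens); on this read-out higher numbers stand for weaker inhibition and lower numbers for stronger inhibition. Compound 1 `COc1cccc(-c2n[nH]cc2N2CCNCC2)c1` carries a methoxy group on its six-membered aromatic ring of carbon only; in this assay compound 1 gives > 10000 nM, which is a limit of the assay and not a number. Compound 2 `c1ccc(-c2n[nH]cc2N2CCNCC2)cc1` has hydrogen in that place; in this assay compound 2 gives > 10000 nM, again a limit. Compound 3 `Clc1cccc(-c2n[nH]cc2N2CCNCC2)c1` carries chloro; in this assay compound 3 gives > 10000 nM, also a limit. All three values share one feature: the limit of > 10000 nM in this assay, at which 3 of the 3 values shown sit. The steps a step that the two limits leave unreadable from compound 1 to compound 2, a step that the two limits leave unreadable from compound 1 to compound 3 and a step that the two limits leave unreadable from compound 2 to compound 3 therefore cannot be read in size or direction.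

Compound 4 `Fc1cccc(-c2n[nH]cc2N2CCNCC2)c1` is not yet measured. It differs from compound 3 in one place: fluoro in place of chloro on an aromatic carbon. Within the data shown here, the steps that bear on this exchange are those among compounds 1, 2 and 3, and none of them gives a readable size; every value shown is a limit. Nothing in the numbers points to a step beyond the scatter. The step from compound 3 to compound 4 is expected to be a step that the limit leaves unreadable from compound 3 to compound 4, with compound 4 most likely again at the limit. Compound 4 is estimated at 15000 nM, between 3000 nM and 60000 nM.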

Compound 4, inhibition constant: 911 nM
Beside the measured number, compound 4's estimate is 16-fold (1.22 log units) above it; measured number outside the range, below it.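

In this assay, among these compounds, the place on the six-membered aromatic ring of carbon only, meta to a large group, proves sensitive to the group it carries, which the earlier compounds could not show: fluoro in place of chloro gives an at least 10-fold lower number from compound 3 to compound 4 (1.04 log units; beyond the scatter). The same holds for the other two groups, with an at least 10-fold lower number from compound 2 to compound 4 (1.04 log units; beyond the scatter) and an at least 10-fold lower number from compound 1 to compound 4 (1.04 log units; beyond the scatter), so a single-atom exchange of chloro for fluoro separates two compounds as clearly as the exchanges from hydrogen and from methoxy do, and all three steps are bounds set by a limit, not exact sizes. Fluoro is the only group shown that yields a number on this read-out, while the others all stay at one limit: the limit of > 10000 nM in this assay, at which 3 of the 4 values shown sit.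

On these data alone, how far compound 1, compound 2 and compound 3 really lie from compound 4 stays unknown, and the steps among those three themselves cannot be read. As far as these compounds go, what a nitrile, a trifluoromethyl or an amine would give at this place, and whether fluoro on another carbon of the ring would give a similar number, also stays open.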